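Trimming a Cyclohexyl to a Methoxy on the Epoxyketone Chain

A few compounds are considered here, and "the series" means these few. Any claim that something is new, unique, unknown or untested is made for them only; others in the source may bear on it.

Compound 1, `COC[C@H](NC(=O)c1cc(C)on1)C(=O)N[C@@H](CC1CCCCC1)C(=O)N[C@@H](CC(C)C)C(=O)[C@@]1(C)CO1`, stands highest of the three numbers in a functional assay on MES-SA cells (Homo sapiens) for cytotoxicity, read by luminescence and CellTiter-Glo, with a stated time of 72 h (a lower number here means a stronger inhibitor, a higher number a weaker inhibitor), giving 210 nM. Compound 3, `COC[C@H](NC(=O)c1cc(C)on1)C(=O)N[C@H](C(=O)N[C@@H](CC(C)C)C(=O)[C@@]1(C)CO1)C(C)C`, differs from it at one side chain and gives 57 nM. Differing from compound 1 in two places, compound 2, `COC[C@H](NC(=O)c1cc(OC)no1)C(=O)N[C@@H](COC)C(=O)N[C@@H](CC(C)C)C(=O)[C@@]1(C)CO1`, gives 12 nM, the lowest number of the set.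

The step to compound 4, `COC[C@H](NC(=O)c1cc(C)on1)C(=O)N[C@@H](COC)C(=O)N[C@@H](CC(C)C)C(=O)[C@@]1(C)CO1`, changes a single position: methoxy in place of cyclohexyl on a saturated chain carbon, two bonds along the chain from an amide-type nitrogen and a carbonyl carbon. Going by the values given here, one measured step bears directly on it: a 3.7-fold lower number from compound 1 to compound 3 (0.57 log units; beyond the scatter), in which a smaller group took the place of the same cyclohexylmethyl side chain. Compound 2 carries the same methoxymethyl side chain that enters in compound 4, but it also differs from compound 1 in a second place, so it gives only a rough pointer; what it shows is that the methoxymethyl-bearing compound 2 sits far below compound 1. Because compound 3 showed a 3.7-fold lower number from compound 1 to compound 3 (0.57 log units; beyond the scatter) for shrinking this side chain, and compound 2 with the methoxymethyl chain reached 12 nM, a clearly lower number is expected for compound 4 in this assay, estimated as an 8.4-fold lower number from compound 1 to compound 4 (0.92 log units; beyond the scatter). Compound 4 is therefore expected to give about 25 nM, with a plausible range from 8 nM to 80 nM.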

Compound 4, half-maximal inhibitory concentration: 22 nM
Compound 4: middle estimate off by 1.1-fold (0.06 log units), on the high side; the range from low to high includes it.
By their numbers in this assay, from the lowest: compounds 2 and 4 (each within the scatter of the next); then compound 3; then compound 1.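

In this assay, methoxymethyl in place of cyclohexylmethyl gives a 9.5-fold lower number from compound 1 to compound 4 (0.98 log units; beyond the scatter), and this single change at the side chain shows directly what compound 2, which differs from compound 1 in two places, could only suggest. The choice among smaller side chains also counts, as methoxymethyl in place of isopropyl gives a 2.6-fold lower number from compound 3 to compound 4 (0.41 log units; beyond the scatter), so the result at this position is not explained simply by removing the cyclohexyl ring. At the other end of the molecule, 5-methyl-1,2-oxazol-3-yl in place of 3-methoxy-1,2-oxazol-5-yl on a carbonyl carbon gives a 1.8-fold higher number from compound 2 to compound 4 (0.26 log units; within the scatter), which lies within the scatter, so these two ring groups cannot be told apart here and the low number of compound 2 travels with its methoxymethyl side chain.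

No measurement shown here explains why methoxymethyl and isopropyl differ or why the cyclohexylmethyl compound gives the highest number. The compounds shown also leave open how this position would respond to a hydroxymethyl or aminomethyl side chain, or to a longer chain such as methoxyethyl.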